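The source may hold more compounds than are shown below. What is called first, only, known or untested is meant among the compounds shown, and "the series" means these compounds.

Measured compounds:
Compound 1, `CC(=O)O[C@@H]1C=CC(=O)O[C@@H]1[C@@H](COC(=O)c1ccc(Cl)cc1)OC(C)=O`: in a functional assay on A549 cells (Homo sapiens) for antiproliferative activity, read by MTT assay, with a stated time of 6 days (a higher number here means a weaker inhibitor, a lower number a stronger inhibitor), compound 1 gives 15700 nM.
Compound 2, `COc1ccc(/C=C/C(=O)OC[C@@H](OCc2ccccc2)[C@H]2OC(=O)C=C[C@H]2OCc2ccccc2)cc1`: in this assay compound 2 gives 4250 nM.
Compound 3, `CC(=O)O[C@@H]1C=CC(=O)O[C@@H]1[C@@H](COC(=O)/C=C/c1ccc([N+](=O)[O-])cc1)OC(C)=O`: in this assay compound 3 gives 2260 nM.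

Among these three numbers compound 2 stands second highest. Its nearest neighbour is compound 3, whose number is lower by an amount that lies within the usual scatter, so no order between compound 2 and compound 3 can be claimed. Its furthest neighbour is compound 1, whose number is higher by a gap that lies beyond the scatter.

Compound 4, `CC(=O)OC[C@@H](OCc1ccccc1)[C@H]1OC(=O)C=C[C@H]1OCc1ccccc1`, has not yet been measured in this assay. It differs from compound 2 in one place: methyl in place of 2-(4-methoxyphenyl)ethenyl on a carbonyl carbon. For the measured compounds named here, no step between measured compounds isolates this exact change, so the expectation rests on what the three numbers show. Compound 1, which carries acetyl groups on its core and gives 15700 nM, stands highest, while the two compounds bearing an aryl-ethenyl carbonyl give the lower numbers. Compound 4 is therefore expected to move toward a higher number, with a step of a 2.6-fold higher number from compound 2 to compound 4 (0.41 log units; beyond the scatter) that should exceed the scatter. The estimate for compound 4 is 11000 nM, in a range from 3500 nM to 35000 nM.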

Compound 4, half-maximal inhibitory concentration: 15000 nM
Compound 4: middle estimate off by 1.4-fold (0.13 log units), on the low side; measured number inside the range.
By their numbers in this assay, from the lowest: compounds 3 and 2 (each within the scatter of the next); then compounds 4 and 1 (each within the scatter of the next).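

For the compounds shown here, replacing 2-(4-methoxyphenyl)ethenyl with methyl on a carbonyl carbon gives, in this assay, a 3.5-fold higher number from compound 2 to compound 4 (0.55 log units; beyond the scatter), the first change here that can be read at one place alone. The step lies beyond the scatter, so the group at this place matters in this assay, and the one with the aromatic ring and the double bond goes with the lower number. Nothing shown gives a reason for this step.

On these data alone, it remains open whether the aromatic ring, the double bond or the methoxy group accounts for the step, and what a 2-phenylethyl chain, a plain phenyl or an amine would give on this carbonyl carbon. As far as these compounds go, whether the same change gives a similar step on a core carrying acetyl groups is also open.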